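The source may hold more compounds than are shown below. What is called first, only, known or untested is meant among the compounds shown, and "the series" means these compounds.

Series so far, in a functional assay on MDA-MB-231 cells (Homo sapiens) for antiproliferative activity, read by MTT assay, with a stated time of 72 h; on this read-out lower numbers stand for stronger inhibition and higher numbers for weaker inhibition:
compound 1 `COc1cc(CCc2ccncc2)cc(OC)c1O`: 6300 nM
compound 2 `COc1cc(CCc2ccccc2)cc(OC)c1O`: > 25000 nM (a limit)
compound 3 `COc1cc(CCc2ccc(F)cc2)cc(OC)c1O`: > 25000 nM (a limit)
compound 4 `COc1cc(CCc2ccccc2Cl)cc(OC)c1O`: not yet measured

Compound 2 has no number in this assay, only a limit: > 25000 nM. Compound 3 likewise gives only a limit: > 25000 nM. Most of the series therefore rests on one reading, (the limit of > 25000 nM in this assay, at which 2 of the 3 values shown sit), and compound 1 alone carries a true number.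

The next change starts from compound 2: chloro in place of hydrogen on an aromatic carbon, ortho to a large group (chloro in place of hydrogen on an aromatic carbon).

The closest measured step is also a halogen for hydrogen, fluoro in that case: a step that the two limits leave unreadable from compound 2 to compound 3. It gives neither a size nor a direction. Among the measured compounds shown here, the only step of readable size is an at least 3.9-fold higher number from compound 1 to compound 2 (0.59 log units; beyond the scatter), and it exchanges pyridin-4-yl for phenyl, a different kind of change, so it says little about a chloro group.

With no readable halogen step, no shift in either direction is expected in this assay beyond the scatter, and a further limit reading is the likeliest result. The expected step is a number no higher from compound 2 to compound 4 (the limit leaves the size open). For compound 4 the estimated value is 25000 nM, with an expected range of 12000 nM to 50000 nM.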

Compound 4, half-maximal inhibitory concentration: 21100 nM
Beside the measured number, compound 4's estimate is 1.2-fold (0.07 log units) above it; low and high end bracket the measured number.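

In this assay, chloro on an aromatic carbon, ortho to a large group, gives the first step from the phenyl compound with a measured value at one end: an at least 1.1-fold lower number from compound 2 to compound 4 (0.07 log units; that floor lies within the scatter). Compound 2 stands at > 25000 nM, which is a limit. The chloro change therefore adds a second true number to the series and the first among the compounds without the pyridin-4-yl group, but its floor supports no claim of a change at this position, and the fluoro step cannot be read, so much of the series still rests on a single reading: the limit of > 25000 nM in this assay, at which 2 of the 4 values shown sit.

Going by these compounds, the true size of the chloro step stays open, as does whether chloro on another aromatic carbon of the same ring would give a measurable value. Also open, on these data alone, is how bromo, an amine or a carboxylic acid would read on this ortho carbon, and what a longer chain in place of the present saturated chain would do to the value on the shared core.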